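This account rests on a few compounds, and the source may have more. Where it says the series, first, only, none or still open, it means among the compounds named here.

Values in an ADME assay on the whole organism (strain Sprague-Dawley) for pharmacokinetics, with Rattus norvegicus as the target, using cassette dosing (a lower number here means slower removal, a higher number faster removal of the compound), for the compounds measured so far

Compound 1 `O[C@]1(Cc2cc(-c3cn[nH]c3)on2)CC[C@H](Cc2ccc(Cl)cc2)CC1` at 11.7 mL/min/kg
Compound 2 `COc1ccc(C[C@H]2CC[C@](O)(Cc3cc(-c4cn[nH]c4)on3)CC2)cc1` at 61.8 mL/min/kg

Compound 2 at 61.8 mL/min/kg holds the higher of the two numbers. Compound 3 `O[C@]1(Cc2cc(-c3cn[nH]c3)on2)CC[C@H](Cc2ccc(F)c(F)c2)CC1` departs from it by 3,4-difluorophenyl in place of 4-methoxyphenyl on a saturated chain carbon bound to a saturated ring carbon with 3,4-difluorophenyl in place of 4-methoxyphenyl on a saturated chain carbon bound to a saturated ring carbon. Going by the values given here, one measured step bears on this change, namely a 5.3-fold higher number from compound 1 to compound 2 (0.72 log units; beyond the scatter) for methoxy in place of chloro on an aromatic carbon, and it lies beyond the scatter. Among the compounds with values here, compound 3 also gives up the methoxy group, but it carries fluorine where compound 1 carries chloro, and no measured compound holds fluorine. Reading that one step backwards, the expected move is a 3.1-fold lower number from compound 2 to compound 3 (0.49 log units; beyond the scatter) in this assay as a lower number of similar or somewhat smaller size. Compound 3 is estimated at 20 mL/min/kg within an expected range of 9 mL/min/kg to 42 mL/min/kg for its clearance.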

Compound 3, clearance: 15.2 mL/min/kg
Compound 3: middle estimate off by 1.3-fold (0.12 log units), on the high side; the range from low to high includes it.
By their numbers in this assay, from the lowest: compounds 1 and 3 (each within the scatter of the next); then compound 2.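

In this assay, 3,4-difluorophenyl in place of 4-methoxyphenyl on a saturated chain carbon bound to a saturated ring carbon gives a 4.1-fold lower number from compound 2 to compound 3 (0.61 log units; beyond the scatter), so the gap to compound 2 no longer rests on the chloro compound alone. Set against 4-chlorophenyl, the same group gives a 1.3-fold higher number from compound 1 to compound 3 (0.11 log units; within the scatter), so the two halogen-bearing rings cannot be told apart in this clearance read-out. Among these three compounds, only the 4-methoxyphenyl of compound 2 stands apart, and no supporting data offer an explanation for this.

Whether the methoxy oxygen itself matters stays open, since an ethyl group, a hydroxyl or a dimethylamino group in its place does not appear among these compounds. From the compounds shown here alone, an unsubstituted phenyl is also absent, so the clearance of the bare ring remains unknown.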